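A thiophene for a pyridine in a cytotoxicity series

A few compounds are considered here, and "the series" means these few. Any claim that something is new, unique, unknown or untested is made for them only; others in the source may bear on it.

Compound 1, `CC(C)N(Cc1cccc(OCCCCCC(=O)O)c1)C(=O)c1ccc(-c2ccncc2)cc1`, is the point of departure for this account. In an ADME assay on HepG2 cells (Homo sapiens) for cytotoxicity, read by CellTiter-Glo and resazurin assay, with a stated time of 72 h (a lower number here means that less compound is needed, a higher number that more compound is needed for the effect), compound 1 reaches only a limit of the assay and not a number, > 26000 nM. Compound 2, `CC(C)N(Cc1cccc(OCCCCCC(=O)O)c1)C(=O)c1ccc(-c2cccc(-c3ccccc3)c2)cc1`, likewise gives a limit in this assay, > 26000 nM. Compound 3, `CC(=O)c1cccc(-c2ccc(C(=O)N(Cc3cccc(OCCCCCC(=O)O)c3)C(C)C)cc2)c1`, also sits at a limit in this assay, > 26000 nM. The steps between these three cannot therefore be read: a step that the two limits leave unreadable from compound 1 to compound 2, a step that the two limits leave unreadable from compound 1 to compound 3 and a step that the two limits leave unreadable from compound 2 to compound 3. What the three have in common is the limit of > 26000 nM in this assay, at which 3 of the 3 values shown sit.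

Compound 4, `CC(C)N(Cc1cccc(OCCCCCC(=O)O)c1)C(=O)c1ccc(-c2ccsc2)cc1`, has not yet been measured. It differs from compound 1 in one place: thiophen-3-yl in place of pyridin-4-yl on an aromatic carbon. For the measured compounds named here, the measured steps all connect compounds 1, 2 and 3 and none has a readable size, so no step gives a number that bears on this change. Because the limit of > 26000 nM in this assay, at which 3 of the 3 values shown sit, holds for every value shown, the expectation is that compound 4 also sits at the limit and that no step beyond the scatter will appear. For compound 4 this means an expected step that the limit leaves unreadable from compound 1 to compound 4. Compound 4 is estimated at 40000 nM, with a range from 20000 nM to 100000 nM.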

Compound 4, half-maximal effective concentration: > 26000 nM
Compound 4: a limit, no number; the forecaster's own chance of this, stated with the estimate: 85%; the middle value does not contradict the limit.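

In this assay compound 4 gives > 26000 nM, which is a limit and not a number, so no new step can be read between it and compound 1, compound 2 or compound 3. The compounds shown leave open whether any group on this aromatic carbon would give a readable number: the limit of > 26000 nM in this assay, at which 4 of the 4 values shown sit.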